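A few compounds are considered here, and "the series" means these few. Any claim that something is new, unique, unknown or untested is made for them only; others in the source may bear on it.

Compound 1 `CC(C)c1onc(-c2c(Cl)cccc2Cl)c1COc1ccc(-c2nc3ccc(C(=O)O)cc3n2C)cc1` is the reference point of this small set. In an assay on HEK-293T cells for antagonist activity at vitamin D3 receptor (Homo sapiens), read by a luciferase reporter, with a stated time of 24 h (a higher number here means a weaker inhibitor, a lower number a stronger inhibitor), compound 1 gives 7150 nM, the highest of the two numbers recorded, with compound 3 `CC(C)Cn1c(-c2ccc(OCc3c(-c4c(Cl)cccc4Cl)noc3C(C)C)cc2)nc2ccc(C(=O)O)cc21` nearest at 1180 nM. Compound 2 `CCCC(CCC)n1c(-c2ccc(OCc3c(-c4c(Cl)cccc4Cl)noc3C(C)C)cc2)nc2ccc(C(=O)O)cc21` returns only a limit in this assay, > 10000 nM, as recorded in the limit of > 10000 nM in this assay, at which 1 of the 3 values shown sits. The step of a 6.1-fold lower number from compound 1 to compound 3 (0.78 log units; beyond the scatter) is modest but beyond the scatter, while an at least 1.3-fold higher number from compound 1 to compound 2 (0.14 log units; that floor lies within the scatter) has a floor that lies within the scatter; the step of an at least 8.4-fold lower number from compound 2 to compound 3 (0.92 log units; beyond the scatter) shows that isobutyl on the aromatic nitrogen is favoured over the larger 1-propylbutyl.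

Compound 4 `CC(C)c1onc(-c2c(Cl)cccc2Cl)c1COc1ccc(-c2nc3ccc(C(=O)O)cc3n2CC2CCCCC2)cc1` has not yet been measured in this assay. It differs from compound 1 by cyclohexyl in place of hydrogen on a saturated chain carbon bound to an aromatic nitrogen. The measured step that bears most directly on it is a 6.1-fold lower number from compound 1 to compound 3 (0.78 log units; beyond the scatter), the same kind of branching at the same place, which lowered the number; the step of an at least 1.3-fold higher number from compound 1 to compound 2 (0.14 log units; that floor lies within the scatter), with a much heavier group on the aromatic nitrogen, went the other way. Because the gain in a 6.1-fold lower number from compound 1 to compound 3 (0.78 log units; beyond the scatter) came from a smaller group than cyclohexyl, the writer expects for compound 4 a smaller gain than compound 3 showed, a step of a 2.9-fold lower number from compound 1 to compound 4 (0.46 log units; beyond the scatter). Compound 4 is therefore estimated at 2500 nM, between 800 nM and 8000 nM.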

Compound 4, half-maximal inhibitory concentration: 346 nM
For compound 4 the middle estimate is 7.2-fold (0.86 log units) above the measured one; the measured number lies below the stated range.
By their numbers in this assay, from the lowest: compound 4; then compound 3; then compound 1. At a limit, above all of these: compound 2.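

On the saturated chain carbon bound to an aromatic nitrogen, the gain in this assay did not shrink as the group grew from isopropyl to cyclohexyl: the full change gives a 21-fold lower number from compound 1 to compound 4 (1.32 log units; beyond the scatter), and cyclohexyl in place of isopropyl gives a further a 3.4-fold lower number from compound 3 to compound 4 (0.53 log units; beyond the scatter). A large group on the aromatic nitrogen is thus not poor as such, and the result for 1-propylbutyl does not extend to every large group, for cyclohexylmethyl in its place gives an at least 28-fold lower number from compound 2 to compound 4 (1.46 log units; beyond the scatter). That step is only a floor, since compound 2 stands at a limit of the assay and not at a number: the limit of > 10000 nM in this assay, at which 1 of the 4 values shown sits.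

The compounds shown leave open whether the gain needs a saturated ring at all, which a phenyl or a cyclopentyl ring on the same carbon, or an open chain such as n-hexyl on the aromatic nitrogen, would begin to answer. They also leave open how far the trend runs beyond cyclohexyl, and whether a hydroxyl group or an amine on that ring would keep the lower number.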